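The compounds below may be only part of what the source reports. "The series", "measured", "known", "first", "only" and "open" are said of these compounds alone.

Compound 1, `CCn1c(C(=O)NCCN)ccc1C(CC)(CC)c1ccc(OCS(=O)(=O)c2ccccc2)c(C)c1`: 6430 nM
Compound 2, `CCn1c(C(=O)N[C@H](C)CO)ccc1C(CC)(CC)c1ccc(OCS(=O)(=O)c2ccccc2)c(C)c1`: 10000 nM

In a functional assay on BXPC-3 cells (Homo sapiens) for antiproliferative activity, read by MTT assay, with a stated time of 24 h (on this read-out lower numbers stand for stronger inhibition and higher numbers for weaker inhibition), compound 2 gives 10000 nM, and its number sits within the usual scatter of that of compound 1, the step being a 1.6-fold higher number from compound 1 to compound 2 (0.19 log units; within the scatter). The next compound, compound 3, `CCn1c(C(=O)N[C@@H](C)C(=O)O)ccc1C(CC)(CC)c1ccc(OCS(=O)(=O)c2ccccc2)c(C)c1`, differs from compound 2 by 1-carboxyethyl in place of 1-(hydroxymethyl)ethyl on an amide-type nitrogen. Within the data shown here, the only measured step that bears on this change is the one from compound 1 to compound 2, a 1.6-fold higher number from compound 1 to compound 2 (0.19 log units; within the scatter), in which the group on the same amide-type nitrogen was exchanged without moving the number beyond the scatter. On that slender basis a step of similar size is expected here, with no clear direction beyond the scatter, so compound 3 is estimated at 12000 nM, within 4000 nM to 36000 nM, which corresponds to an expected step of a 1.2-fold higher number from compound 2 to compound 3 (0.08 log units; within the scatter).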

Compound 3, half-maximal inhibitory concentration: 20800 nM
Compound 3: the middle estimate sits 1.7-fold (0.24 log units) below what was measured, and the stated range covers the measured number.
By their numbers in this assay, from the lowest: compounds 1 and 2 (each within the scatter of the next); then compound 3.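

In this assay, a change at this amide-type nitrogen now moves the number beyond the scatter: 1-carboxyethyl in place of 1-(hydroxymethyl)ethyl gives a 2.1-fold higher number from compound 2 to compound 3 (0.32 log units; beyond the scatter) in a modest step, and 1-carboxyethyl in place of 2-aminoethyl gives a 3.2-fold higher number from compound 1 to compound 3 (0.51 log units; beyond the scatter) in another modest step. The position is therefore not indifferent to the group it carries, and among these compounds, compound 3 is the weakest inhibitor. The data given offer no explanation for this shift.

On these data alone, it remains open whether a methyl ester or a longer chain ending in a carboxylic acid would behave like 1-carboxyethyl. The mirror-image form of 1-carboxyethyl would show whether the defined stereocentre matters here.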